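The compounds below may be only part of what the source reports. "The series", "measured", "known", "first", "only" and "open" are said of these compounds alone.

In a functional assay on DU-145 cells (Homo sapiens) for inhibition, read by trypan blue exclusion, with a stated time of 96 h (on this read-out lower numbers stand for stronger inhibition of growth and higher numbers for weaker inhibition of growth), compound 1 `O=C(O)c1ccc(C(=O)/C(=C\c2ccc(Br)c([N+](=O)[O-])c2)SCc2ccc(Br)cc2)cc1` gives 1000 nM, and compound 2 `O=C(O)c1ccc(C(=O)/C(=C\c2ccc(Br)cc2)SCc2ccc(Br)cc2)cc1` gives 1000 nM; the step between them reads no change at the digits printed from compound 1 to compound 2 (within the scatter). Compound 3 `CN(C)c1ccc(/C=C(/SCc2ccc(Br)cc2)C(=O)c2ccc(C(=O)O)cc2)cc1` gives 50000 nM, the highest of the three numbers and so the weakest growth inhibition in this set. The two steps that lead to compound 3 are large: a 50-fold higher number from compound 1 to compound 3 (1.70 log units; beyond the scatter) and a 50-fold higher number from compound 2 to compound 3 (1.70 log units; beyond the scatter). Compound 4 `CN1CCN(/C=C(/SCc2ccc(Br)cc2)C(=O)c2ccc(C(=O)O)cc2)CC1[N+](=O)[O-]` differs from compound 3 in one place: 4-methyl-3-nitropiperazin-1-yl in place of 4-(dimethylamino)phenyl on a double-bonded chain carbon bound to a double-bonded chain carbon. For the measured compounds named here, no measured step exchanges the six-membered aromatic ring of carbon only for a six-membered non-aromatic ring with 2 hetero atoms on a double-bonded chain carbon bound to a double-bonded chain carbon, so the measured steps bear on this change only loosely; they show that a change there can move the number a long way, in either direction in principle. For compound 4 the expected step is a 1.7-fold lower number from compound 3 to compound 4 (0.22 log units; within the scatter), with wide uncertainty. Compound 4 is thus estimated at 30000 nM, between 3000 nM and 200000 nM.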

Compound 4, concentration for 50% growth inhibition: 10000 nM
Estimate against measurement, compound 4: 3.0-fold (0.48 log units) above; the measured number falls inside the stated range.
By their numbers in this assay, from the lowest: compounds 1 and 2 (each within the scatter of the next); then compound 4; then compound 3.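

In this assay, for the compounds shown here, the 4-methyl-3-nitropiperazin-1-yl group is the first group at this place, on a double-bonded chain carbon bound to a double-bonded chain carbon, without a six-membered aromatic ring of carbon only, and it gives a 5.0-fold lower number from compound 3 to compound 4 (0.70 log units; beyond the scatter). The same change read against the two bromophenyl compounds gives a 10-fold higher number from compound 2 to compound 4 (1.00 log units; beyond the scatter) and a 10-fold higher number from compound 1 to compound 4 (1.00 log units; beyond the scatter), so this non-aromatic ring places compound 4 in the gap that compound 3 had opened from compound 1 and compound 2, without closing it. Nothing available here explains these steps.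

Compound 4 brings in the ring and the nitro group together, so the compounds shown do not separate what each contributes. Going by these compounds, how a plain 4-methylpiperazin-1-yl group or a morpholine ring would read at this place remains open.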